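Pyrazolyl swap on the shared core

A few compounds are considered here, and "the series" means these few. Any claim that something is new, unique, unknown or untested is made for them only; others in the source may bear on it.

In a functional assay on CHO cells for antagonist activity at sphingosine 1-phosphate receptor 2 (Homo sapiens), read by scintillation counting and GTPgammaS binding, with a stated time of 4 h, in the presence of a further agent that is not named here (on this read-out lower numbers stand for stronger inhibition and higher numbers for weaker inhibition), compound 1 `Cc1cc(NNC(=O)Nc2cc(Cl)nc(Cl)c2)ncc1N(C)C` gives 5.3 nM and compound 2 `Cc1cc(NNC(=O)Nc2cc(Cl)nc(Cl)c2)ncc1C#N` gives 7 nM, with a 1.3-fold higher number from compound 1 to compound 2 (0.12 log units; within the scatter) between them. Compound 3 `Cc1cc(NNC(=O)Nc2cc(Cl)nc(Cl)c2)ncc1-c1ccn(C)n1` gives 9.3 nM, the highest of the three numbers shown, yet both a 1.8-fold higher number from compound 1 to compound 3 (0.24 log units; within the scatter) and a 1.3-fold higher number from compound 2 to compound 3 (0.12 log units; within the scatter) remain within the scatter, so the three sit together. Compound 4 `Cc1cc(NNC(=O)Nc2cc(Cl)nc(Cl)c2)ncc1-c1cn(C)nc1C` carries 1,3-dimethyl-1H-pyrazol-4-yl in place of 1-methyl-1H-pyrazol-3-yl on an aromatic carbon. Among the measured compounds shown here, the two steps that touch this ring carbon, from dimethylamino or cyano to 1-methyl-1H-pyrazol-3-yl, were small, and no measured step shows this position moving the number beyond the scatter. A further pyrazolyl is therefore expected to change little: a 1.0-fold lower number from compound 3 to compound 4 (0.01 log units; within the scatter) is expected to lie within the scatter. Compound 4 is estimated at 9 nM, in the range 4 nM to 22 nM.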

Compound 4, half-maximal inhibitory concentration: 0.8 nM
Beside the measured number, compound 4's estimate is 11-fold (1.05 log units) above it, and the stated range ends above it.
By their numbers in this assay, from the lowest: compound 4; then compounds 1, 2 and 3 (each within the scatter of the next).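

This position is not indifferent to the group it carries in this assay: 1,3-dimethyl-1H-pyrazol-4-yl gives a 12-fold lower number from compound 3 to compound 4 (1.07 log units; beyond the scatter) and stands apart from the other two groups as well, with an 8.8-fold lower number from compound 2 to compound 4 (0.94 log units; beyond the scatter) and a 6.6-fold lower number from compound 1 to compound 4 (0.82 log units; beyond the scatter) on the same read-out. Dimethylamino, cyano and 1-methyl-1H-pyrazol-3-yl stayed within the scatter of one another, so the pyrazole's substitution and attachment matter where the swap among those three did not show it. No evidence at hand accounts for this step.

Still open, as far as these compounds go, is whether the extra methyl or the shift from 3-yl to 4-yl attachment carries the step, which 1-methyl-1H-pyrazol-4-yl would separate. Also open, from the compounds shown here alone, is how 1,3-diethyl-1H-pyrazol-4-yl would read here.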